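Swapping the hexyl chain for a furan-bearing group

The source may report more compounds than this note shows. Statements on the series, on what has been measured and on what is new or still open speak of the compounds shown alone.

Going by the values given here, compound 2 `CCCCCCN1C(=O)COCC(NC(=O)OCc2ccccc2)C1=O` stands highest of the two numbers so far in a functional assay on the whole organism (strain ICR) with Mus musculus as the target, in the maximal electroshock model, with a stated time of 30 min (on this read-out higher numbers stand for an effect only at larger amounts of compound and lower numbers for an effect already at smaller amounts), giving 87.5 mg/kg, while compound 1 `O=C1COCC(NC(=O)OCc2ccccc2)C(=O)N1` gives 81.3 mg/kg. Among the compounds with values here, the one measured step, a 1.1-fold higher number from compound 1 to compound 2 (0.03 log units; within the scatter), shows that adding a hexyl chain to the ring nitrogen changed little. Compound 3 `O=C(NC1COCC(=O)N(Cc2ccco2)C1=O)OCc1ccccc1` differs from compound 2 by furan-2-yl in place of pentyl on a saturated chain carbon bound to an amide-type nitrogen in a ring. Within the data shown here, no measured step covers a ring entering in place of a chain, so the only guide is a 1.1-fold higher number from compound 1 to compound 2 (0.03 log units; within the scatter), and no step beyond the scatter is expected. Compound 3 is expected to give 80 mg/kg, with a range from 40 mg/kg to 170 mg/kg. That estimate amounts to a 1.1-fold lower number from compound 2 to compound 3 (0.04 log units; within the scatter).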

Compound 3, dose for half-maximal effect: > 100 mg/kg
Compound 3 ended at the assay's limit; the forecaster's own chance of this, stated with the estimate: 10%; at least 1.2-fold (0.09 log units) between middle value and limit.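

In this assay, compound 3 gives > 100 mg/kg, which is a limit of the assay and not a number: the limit of > 100 mg/kg in this assay, at which 1 of the 3 values shown sits.

The swap on the chain reads an at least 1.1-fold higher number from compound 2 to compound 3 (0.05 log units; that floor lies within the scatter), and the full group on the amide-type nitrogen in a ring reads an at least 1.2-fold higher number from compound 1 to compound 3 (0.08 log units; that floor lies within the scatter). So furan-2-yl in place of pentyl brought no lower number here, though the true size of either step stays unknown.

Still open, as far as these compounds go, is whether a longer chain, an amine or a carboxylic acid on this nitrogen would move the number clearly away from that of compound 1.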